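A few compounds are considered here, and "the series" means these few. Any claim that something is new, unique, unknown or untested is made for them only; others in the source may bear on it.

In a functional assay on A549 cells (Homo sapiens) for cytotoxicity, read by MTT assay, with a stated time of 72 h (on this read-out lower numbers stand for stronger inhibition and higher numbers for weaker inhibition), compound 2 `COc1cc2c(Oc3ccc(NC(=O)c4nccc(-c5ccc(C)cc5)n4)cc3F)ccnc2cc1OCCCN1CCCCC1` gives 900 nM, the higher of the two numbers in hand. Compound 1 `COc1cc2c(Oc3ccc(NC(=O)c4cc(-c5ccccc5)ccn4)cc3F)ccnc2cc1OCCCN1CCN(C)CC1` gives 340 nM, and that gap lies beyond the scatter. Compound 3 `COc1cc2c(Oc3ccc(NC(=O)c4nccc(-c5ccc(F)cc5F)n4)cc3F)ccnc2cc1OCCCN1CCCCC1` differs from compound 2 in one place: 2,4-difluorophenyl in place of 4-methylphenyl on an aromatic carbon. Among the measured compounds shown here, no step between measured compounds matches this change, so there is no direct precedent to lean on. For compound 3 only a modest shift is expected, a 1.1-fold lower number from compound 2 to compound 3 (0.05 log units; within the scatter), with no confident direction. The estimated value for compound 3 in this assay is 800 nM, within a range from 300 nM to 2500 nM.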

Compound 3, half-maximal inhibitory concentration: 470 nM
Compound 3: middle estimate off by 1.7-fold (0.23 log units), on the high side; measured number inside the range.
By their numbers in this assay, from the lowest: compounds 1, 3 and 2 (each within the scatter of the next, the first and the last beyond it).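

In this assay, among the compounds shown here, the first step at this aromatic carbon, 2,4-difluorophenyl in place of 4-methylphenyl, gives a 1.9-fold lower number from compound 2 to compound 3 (0.28 log units; within the scatter). Within this pair, the two substituted phenyl groups therefore cannot be told apart, even though one carries two fluorines and the other a methyl. Nothing measured here bears on this result.

On these data alone, whether a carboxylic acid or an amine on this carbon would move the number beyond the scatter remains open. Compound 1 differs from both in more than one place, so its number cannot be tied to any single group.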